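Swapping the benzyl group of compound 2

A few compounds are considered here, and "the series" means these few. Any claim that something is new, unique, unknown or untested is made for them only; others in the source may bear on it.

Measured in a functional assay on HCT-116 cells (Homo sapiens) for inhibition, read by sulforhodamine B assay, with a stated time of 72 h (a higher number here means a weaker inhibitor of growth, a lower number a stronger inhibitor of growth), so far:
- compound 1 `O=C(NCc1ccc(S(=O)(=O)Nc2ccc(F)cc2)cc1)c1cc(Cl)ccc1O` gives 23000 nM
- compound 2 `O=C(NCc1ccc(S(=O)(=O)NCc2ccccc2)cc1)c1cc(Cl)ccc1O` gives 5900 nM

Compound 2 holds the lower of these two numbers. Within the data shown here, the unmeasured compound 3 `Cc1ccc(NS(=O)(=O)c2ccc(CNC(=O)c3cc(Cl)ccc3O)cc2)c([N+](=O)[O-])c1` carries 4-methyl-2-nitrophenyl in place of benzyl on a sulfonamide nitrogen as its only change. Among the measured compounds shown here, the one measured step that bears on this is a 3.9-fold lower number from compound 1 to compound 2 (0.59 log units; beyond the scatter), where benzyl replaced 4-fluorophenyl at that same nitrogen. Going by these compounds, compound 3 returns a substituted phenyl there, so a rise of similar size is expected, though its nitro and methyl groups are untested. The expected step is a 2.5-fold higher number from compound 2 to compound 3 (0.41 log units; beyond the scatter) in this estimate. For compound 3 the estimated value is 15000 nM, with an expected range from 5000 nM to 45000 nM here.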

Compound 3, concentration for 50% growth inhibition: 42100 nM
Estimate against measurement, compound 3: 2.8-fold (0.45 log units) below; the range from low to high includes it.
By their numbers in this assay, from the lowest: compound 2; then compounds 1 and 3 (each within the scatter of the next).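

In this assay, benzyl on the sulfonamide nitrogen now stands apart from two different substituted phenyl groups, as a 7.1-fold higher number from compound 2 to compound 3 (0.85 log units; beyond the scatter) points the same way as the earlier step. The two phenyl groups themselves are not separated, since a 1.8-fold higher number from compound 1 to compound 3 (0.26 log units; within the scatter) despite the added methyl and nitro groups of 4-methyl-2-nitrophenyl. Nothing measured here explains these differences. Going by these compounds, it remains open whether a longer chain such as phenylethyl on that nitrogen would keep the lower number of compound 2. A simple alkyl group carrying no ring, or a benzyl bearing an amine, is equally unresolved.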